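From Compound 3 to a Larger Group on the Nitrogen

A few compounds are considered here, and "the series" means these few. Any claim that something is new, unique, unknown or untested is made for them only; others in the source may bear on it.

In a functional assay on A549 cells (Homo sapiens) for antiproliferative activity, read by MTT assay (on this read-out higher numbers stand for weaker inhibition and lower numbers for stronger inhibition), compound 1 `COc1cc2c(Oc3ccc(NC(=O)Nc4ccccc4)cc3)ccnc2cc1OCCCCCCC(=O)NO` gives 1650 nM, compound 2 `COc1cc2c(Oc3ccc(NC(=O)Nc4ccc(OC(F)(F)F)cc4)cc3)ccnc2cc1OCCCCCCC(=O)NO` gives 3130 nM, and compound 3 `COc1cc2c(Oc3ccc(NC(=O)Nc4ccccc4F)cc3)ccnc2cc1OCCCCCCC(=O)NO` gives 870 nM. Compound 3 therefore matches compound 1 within the scatter and stands clearly apart only from compound 2.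

Compound 4 `COc1cc2c(Oc3ccc(NC(=O)N/N=C/c4ccccc4F)cc3)ccnc2cc1OCCCCCCC(=O)NO` keeps the shared core but alters what sits on an amide-type nitrogen: a group of 9 heavy atoms (7 carbon, 1 nitrogen, 1 fluorine; one six-membered aromatic ring of carbon only) in place of a group of 7 heavy atoms (6 carbon, 1 fluorine; one six-membered aromatic ring of carbon only), on an amide-type nitrogen. Among the measured compounds shown here, no measured step makes this kind of change, so the evidence is indirect. The nearest guides are steps that altered only the aromatic group at the end of that arm. Two stayed small, a 1.9-fold higher number from compound 1 to compound 2 (0.28 log units; within the scatter) and a 1.9-fold lower number from compound 1 to compound 3 (0.28 log units; within the scatter), and the largest was modest, a 3.6-fold lower number from compound 2 to compound 3 (0.56 log units; beyond the scatter).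

Since that end group has moved the number only modestly so far, a large shift is not expected here, though the uncertainty is wide. The expected step is a 1.3-fold higher number from compound 3 to compound 4 (0.10 log units; within the scatter), which is no move beyond the scatter. Compound 4 is estimated at 1100 nM, with an expected range from 350 nM to 3300 nM.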

Compound 4, half-maximal inhibitory concentration: 7780 nM
For compound 4 the middle estimate is 7.1-fold (0.85 log units) below the measured one; the measured number lies above the stated range.
By their numbers in this assay, from the lowest: compounds 3, 1 and 2 (each within the scatter of the next, the first and the last beyond it); then compound 4.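

In this assay, changes confined to the aromatic end group had moved the number only modestly, but the group entering on the amide-type nitrogen, with its added nitrogen and its double bond outside the ring, gives an 8.9-fold higher number from compound 3 to compound 4 (0.95 log units; beyond the scatter). The same weakening appears against the other two compounds, with a 4.7-fold higher number from compound 1 to compound 4 (0.67 log units; beyond the scatter) and a 2.5-fold higher number from compound 2 to compound 4 (0.40 log units; beyond the scatter), so compound 4 is the weakest of the four, beyond the scatter from each of the others. This shows that the link between the amide-type nitrogen and the aromatic ring matters more on this read-out than the end group does, though no measurement at hand explains the loss.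

The compounds shown leave open whether the added nitrogen, the double bond or the greater size of the group accounts for the change. A saturated methylene link in place of the double bond, or a plain benzyl group on the amide-type nitrogen, would help tell these apart.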